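The source may report more compounds than this note shows. Statements on the series, on what has been measured and on what is new or still open speak of the compounds shown alone.

Measured compounds:
compound 1 `CN(C)c1ccc(N2C(=O)NC3(CSC4=C3C(=O)c3ncccc3C4=O)C2=O)cc1`: 800 nM
compound 2 `CCCc1ccc(N2C(=O)NC3(CSC4=C3C(=O)c3ncccc3C4=O)C2=O)cc1`: 450 nM
compound 3 `O=C1NNC(=O)C2(CSC3=C2C(=O)c2ncccc2C3=O)N1`: 5000 nM

All three were tested in a functional assay on XF498 cells (Homo sapiens) for antiproliferative activity, read by MTT assay, with a stated time of 96 h; a lower number here means a stronger inhibitor, a higher number a weaker inhibitor. Among these three numbers compound 2 has the lowest. Compound 1 stands nearest, its number higher only within the usual scatter, while compound 3 stands furthest, its number higher by an amount beyond the scatter.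

The unmeasured compound 4 `O=C1NC(=O)C2(CSC3=C2C(=O)c2ncccc2C3=O)N1` arises from compound 2 by a single change: hydrogen in place of 4-propylphenyl on an amide-type nitrogen in a ring. Within the data shown here, the only measured one-place step, a 1.8-fold lower number from compound 1 to compound 2 (0.25 log units; within the scatter), exchanges one group for another on the very aromatic ring that is now removed entirely, so it says little about losing that ring. Compound 3 also lacks an aryl group on its shared core, though its ring that carries the nitrogens differs from that of compound 4 as well; compound 3 gives 5000 nM where compound 2 gives 450 nM.

On that basis the number for compound 4 in this assay is expected to rise, a 6.7-fold higher number from compound 2 to compound 4 (0.82 log units; beyond the scatter). Compound 4 is therefore estimated at 3000 nM, with a range from 1000 nM to 10000 nM.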

Compound 4, half-maximal inhibitory concentration: 3120 nM
The estimate for compound 4 lay 1.0-fold (0.02 log units) below the measured number; the measured number falls inside the stated range.
By their numbers in this assay, from the lowest: compounds 2 and 1 (each within the scatter of the next); then compounds 4 and 3 (each within the scatter of the next).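

In this assay, removing the whole aryl group from this ring nitrogen weakens the compound: the change gives a 6.9-fold higher number from compound 2 to compound 4 (0.84 log units; beyond the scatter) and also a 3.9-fold higher number from compound 1 to compound 4 (0.59 log units; beyond the scatter), whereas the earlier step only exchanged one group for another on the aromatic ring. At this amide-type nitrogen, then, both aryl groups give lower numbers than hydrogen, although the shared core without an aryl group still has a measurable number, with compound 4 at 3120 nM in this assay. Nothing available here bears on the reason for this difference.

The compounds shown leave open whether the aromatic ring itself is needed, or whether a simple methyl or a longer alkyl chain on this nitrogen would also bring the number down. They also leave open how a carboxylic acid on the aromatic ring would compare with propyl or dimethylamino.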